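Notes on the ring-nitrogen substituent of compound 2

A few compounds are considered here, and "the series" means these few. Any claim that something is new, unique, unknown or untested is made for them only; others in the source may bear on it.

Compound 1 `CC(=O)N1CCN(c2nc(Nc3ccc(C#N)c(C(F)(F)F)c3)nc(Oc3ccnc4ccccc34)n2)CC1` gives 75100 nM in a functional assay on DU-145 cells (Homo sapiens) for cytotoxicity, read by sulforhodamine B assay, with a stated time of 48 h; on this read-out lower numbers stand for stronger inhibition of growth and higher numbers for weaker inhibition of growth. Compound 2 `N#Cc1ccc(Nc2nc(Oc3ccnc4ccccc34)nc(N3CCN(c4cccc(C(F)(F)F)c4)CC3)n2)cc1C(F)(F)F` gives 38700 nM in this assay. Compound 3 `COc1ccc(CN2CCN(c3nc(Nc4ccc(C#N)c(C(F)(F)F)c4)nc(Oc4ccnc5ccccc45)n3)CC2)c(OC)c1OC` reaches only a limit of the assay, > 100000 nM, in this assay. Compound 2 stands beside compound 1 rather than apart from it, since a 1.9-fold lower number from compound 1 to compound 2 (0.29 log units; within the scatter) lies within the scatter; the third value shown is a limit, as the limit of > 100000 nM in this assay, at which 1 of the 3 values shown sits, records.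

The step to compound 4 `N#Cc1ccc(Nc2nc(Oc3ccnc4ccccc34)nc(N3CCN(c4ncccn4)CC3)n2)cc1C(F)(F)F` is pyrimidin-2-yl in place of 3-(trifluoromethyl)phenyl on an amine nitrogen in a ring. Within the data shown here, the only measured step at that amine nitrogen in a ring, a 1.9-fold lower number from compound 1 to compound 2 (0.29 log units; within the scatter), was within the scatter, and compound 3, which also differs at that amine nitrogen in a ring, gave only a limit. Among the measured compounds shown here, no measured step therefore supports a shift beyond the scatter in this assay in either direction, while the limit of compound 3 shows that a weaker number at this position is possible. The expected value for compound 4 is 50000 nM, with a range from 15000 nM to 150000 nM. This expectation corresponds to a 1.3-fold higher number from compound 2 to compound 4 (0.11 log units; within the scatter), a step estimated to remain within the scatter.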

Compound 4, concentration for 50% growth inhibition: 85200 nM
Compound 4: middle estimate off by 1.7-fold (0.23 log units), on the low side; measured number inside the range.
By their numbers in this assay, from the lowest: compounds 2, 1 and 4 (each within the scatter of the next, the first and the last beyond it). At a limit, above all of these: compound 3.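

In this assay this amine nitrogen now gives its first step beyond the scatter, though a modest one: a 2.2-fold higher number from compound 2 to compound 4 (0.34 log units; beyond the scatter) with pyrimidin-2-yl in place of 3-(trifluoromethyl)phenyl, so exchanging one six-membered aromatic ring for another at this position can move the number. Among these compounds, the second new step, a 1.1-fold higher number from compound 1 to compound 4 (0.05 log units; within the scatter) with pyrimidin-2-yl in place of acetyl, does not separate those two groups, so the only separation among the numbers at this position remains the one between the two aromatic groups. Among the compounds shown here, compound 3 remains a limit and not a number, and it gives no measurable step: the limit of > 100000 nM in this assay, at which 1 of the 4 values shown sits.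

The step from 3-(trifluoromethyl)phenyl to pyrimidin-2-yl changes the trifluoromethyl group and the ring nitrogens together, and the data cannot assign the shift to either; an unsubstituted phenyl or a pyridin-2-yl group on this nitrogen would divide the two changes. Also open, from the compounds shown here alone, is how a simple alkyl chain, a primary amine or a carboxylic acid at this position would compare with the aromatic groups and with acetyl.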